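The source may hold more compounds than are shown below. What is called first, only, known or untested is meant among the compounds shown, and "the series" means these compounds.

Notes on the series in a functional assay on HeLa cells (Homo sapiens) for antiproliferative activity, read by MTT assay, with a stated time of 72 h; a higher number here means a weaker inhibitor, a lower number a stronger inhibitor. Compound 1 `O=C1COc2ccc(-c3cccc(NS(=O)(=O)c4ccc(F)cc4)c3)cc2N1` carries a hydrogen on the amide-type nitrogen in the ring. In this assay compound 1 gives only the assay limit of > 40000 nM. Compound 3 `COc1cccc(N2C(=O)COc3ccc(-c4cccc(NS(=O)(=O)c5ccc(F)cc5)c4)cc32)c1` carries a 3-methoxyphenyl at that position. Compound 3 likewise reaches only the limit of > 40000 nM. The step that the two limits leave unreadable from compound 1 to compound 3 is unreadable: both ends rest at the limit of > 40000 nM in this assay, at which 2 of the 3 values shown sit. Going by the values given here, compound 2 `COc1ncc(-c2ccc3c(c2)N(c2ccccc2)C(=O)CO3)cc1NS(=O)(=O)c1ccc(F)cc1` differs from compound 3 in more than one place, so no single step is counted; in this assay compound 2 gives 1530 nM. Compound 4 `CC(C)N1C(=O)COc2ccc(-c3cccc(NS(=O)(=O)c4ccc(F)cc4)c3)cc21` is yet to be measured. Change from compound 3: isopropyl in place of 3-methoxyphenyl on an amide-type nitrogen in a ring. Among the compounds with values here, no measured step bears on this change, and the only numerical value in the set comes from compound 2, which also differs in another ring. Compound 4 is therefore expected to stay near the limit, the estimated step being an at least 2.0-fold lower number from compound 3 to compound 4 (0.30 log units; that floor lies within the scatter). The estimate for compound 4 is 20000 nM, between 3000 nM and 40000 nM, with a fair chance that only a limit is reported.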

Compound 4, half-maximal inhibitory concentration: 22700 nM
For compound 4 the middle estimate is 1.1-fold (0.05 log units) below the measured one; measured number inside the range.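

In this assay, going by these compounds alone, compound 4 is the first compound on the core of compound 1 to give a number rather than a limit, so this position on the amide-type nitrogen in the ring can carry a value within the range of the assay. The new steps read an at least 1.7-fold lower number from compound 3 to compound 4 (0.24 log units; that floor lies within the scatter) and an at least 1.7-fold lower number from compound 1 to compound 4 (0.24 log units; that floor lies within the scatter), and since both are floors, neither yet establishes a change beyond the scatter. Compound 1 and compound 3 both rest at a limit and not at a number: the limit of > 40000 nM in this assay, at which 2 of the 4 values shown sit.

From the compounds shown here alone, the true size of both steps stays open, as does the ranking of hydrogen, 3-methoxyphenyl and isopropyl at this position. Also open, going by these compounds, is whether a methyl group, a longer chain such as n-butyl, or a chain ending in an amine would give a clearly lower number here.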